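The source may hold more compounds than are shown below. What is called first, only, known or untested is meant among the compounds shown, and "the series" means these compounds.

Of the compounds shown here, two have been measured in a functional assay for antagonist activity at Neuropeptide Y receptor type 5 (Homo sapiens); on this read-out higher numbers stand for weaker inhibition and lower numbers for stronger inhibition. Compound 1 `O=C1O[C@]2(CC[C@H](CNc3ccc(C(F)(F)F)cn3)CC2)CN1c1ccccn1` gives 1 nM in this assay, and compound 2 `Cc1ncccc1N1C[C@]2(CC[C@@H](CNc3cnn(-c4ccccc4F)c3)CC2)OC1=O` gives 0.631 nM. Compound 1 stands at the higher of the two numbers, but its gap to compound 2 lies within the scatter of such measurements, so the two cannot be told apart on these data. The unmeasured compound 3 `O=C1O[C@]2(CC[C@H](CNc3ccc(-c4ncccn4)cn3)CC2)CN1c1ccccn1` is derived from compound 1 by a single change: pyrimidin-2-yl in place of trifluoromethyl on an aromatic carbon. Among the compounds with values here, no measured pair shows a replacement of this kind, so the size of the step has no precedent here. With both known values so low, the account expects compound 3 to come out near compound 1 or somewhat higher in this assay, a step of modest size that may not exceed the scatter. The estimate for compound 3 in this assay is 2 nM, with a range from 0.4 nM to 10 nM. That estimate means an expected step of a 2.0-fold higher number from compound 1 to compound 3 (0.30 log units; within the scatter).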

Compound 3, inhibition constant: 0.159 nM
Estimate against measurement, compound 3: 13-fold (1.10 log units) above; the whole stated range lies above it.
By their numbers in this assay, from the lowest: compound 3; then compounds 2 and 1 (each within the scatter of the next).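

At this position, on an aromatic carbon two atoms from the ring nitrogen and para to a large group, the core of compound 1 accepts far more than trifluoromethyl: in this assay, pyrimidin-2-yl in its place gives a 6.3-fold lower number from compound 1 to compound 3 (0.80 log units; beyond the scatter). The position therefore tolerates an aromatic ring carrying hydrogen-bond acceptors, and the change brings a gain beyond the scatter rather than a loss, although this rests on a single pair. Nothing measured here accounts for that gain.

What a phenyl or a pyridin-2-yl group would do at this place stays open, so the compounds shown do not separate the contribution of the ring from that of its nitrogen atoms. As far as these compounds go, whether an amine or a longer chain would also be accepted here is equally open.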